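This account rests on a few compounds, and the source may have more. Where it says the series, first, only, none or still open, it means among the compounds named here.

Values measured in a functional assay on K562 cells (Homo sapiens), read by MTT assay, with a stated time of 72 h; on this read-out lower numbers stand for stronger inhibition and higher numbers for weaker inhibition:
Compound 1 `CNc1ncnc2c1c(-c1ccco1)cn2[C@@H]1O[C@H](CO)[C@@H](O)[C@H]1O`: 15100 nM
Compound 2 `CNc1ncnc2c1c(-c1ccccc1)cn2[C@@H]1O[C@H](CO)[C@@H](O)[C@H]1O`: > 20000 nM (a limit of the assay, not a number)
Compound 3 `C#Cc1cn([C@@H]2O[C@H](CO)[C@@H](O)[C@H]2O)c2ncnc(NC)c12`: 1380 nM

Compound 3 holds the lowest of the two actual numbers. Compound 4 `C#Cc1cn([C@@H]2O[C@H](CO)[C@@H](O)[C@H]2O)c2ncnc(N(C)C)c12` differs from it by methyl in place of hydrogen on a nitrogen on an aromatic ring, methylamino to dimethylamino (methyl in place of hydrogen on a nitrogen on an aromatic ring). The measured steps all change a group on an aromatic carbon instead. Ethynyl in place of furan-2-yl gave an 11-fold lower number from compound 1 to compound 3 (1.04 log units; beyond the scatter), and ethynyl in place of phenyl gave an at least 14-fold lower number from compound 2 to compound 3 (1.16 log units; beyond the scatter). Neither touches this nitrogen, so they bear only indirectly and set no size for the new step. In this assay a modest move toward a higher number is expected, an estimated 2.0-fold higher number from compound 3 to compound 4 (0.31 log units; beyond the scatter). The expected value for compound 4 is 2800 nM, with an estimated range of 800 nM to 10000 nM.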

Compound 4, half-maximal inhibitory concentration: 260 nM
For compound 4 the middle estimate is 11-fold (1.03 log units) above the measured one, and the stated range ends above it.
By their numbers in this assay, from the lowest: compound 4; then compound 3; then compound 1. At a limit, above all of these: compound 2.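

In this assay, methylamino to dimethylamino on this nitrogen on an aromatic ring gives a 5.3-fold lower number from compound 3 to compound 4 (0.72 log units; beyond the scatter) and so places compound 4 lowest among the measured values. The earlier steps shown here changed only a group on an aromatic carbon, and this step shows that the nitrogen is also a position where a single methyl moves the number beyond the scatter. Nothing measured here explains the step. As far as these compounds go, whether an ethyl group or a pyrrolidine ring at this nitrogen would go lower remains open. So does whether dimethylamino has the same effect alongside furan-2-yl or phenyl.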